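A few compounds are considered here, and "the series" means these few. Any claim that something is new, unique, unknown or untested is made for them only; others in the source may bear on it.

Measured so far in a functional assay on MDA-MB-231 cells (Homo sapiens) for cytotoxicity, read by sulforhodamine B assay, tested at 10 uM; on this read-out higher numbers stand for more inhibition at the one concentration tested (going by the name of the read-out) and lower numbers for less inhibition:
compound 1 `CCCCCc1cc(-c2cn([C@H]3C[C@H](OC(C)=O)[C@@H](COC(C)=O)O3)c(=O)[nH]c2=O)on1`: 91.5%
compound 2 `CC(=O)OC[C@H]1O[C@@H](n2cc(-c3cc(-c4ccccc4)no3)c(=O)[nH]c2=O)C[C@@H]1OC(C)=O`: 95%
compound 3 `CCc1ccc(-c2cc(-c3cn([C@H]4C[C@H](OC(C)=O)[C@@H](COC(C)=O)O4)c(=O)[nH]c3=O)on2)cc1`: 97.4%

Compound 3 gives the highest of the three numbers, but the gaps to its neighbours are small: a number 2.4 percentage points higher from compound 2 to compound 3 (within the scatter) and a number 5.9 percentage points higher from compound 1 to compound 3 (within the scatter), both within the scatter, so the three compounds are not separable on these data.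

The next compound, compound 4 `CC(=O)OC[C@H]1O[C@@H](n2cc(-c3cc(C)no3)c(=O)[nH]c2=O)C[C@@H]1OC(C)=O`, is reached from compound 3 by a single change: methyl in place of 4-ethylphenyl on an aromatic carbon. The group taken off the five-membered ring is the largest yet varied there.

Within the data shown here, three measured steps touch this position. a number 3.5 percentage points higher from compound 1 to compound 2 (within the scatter) and a number 5.9 percentage points higher from compound 1 to compound 3 (within the scatter) show that swapping the pentyl chain for a phenyl or a 4-ethylphenyl left the number where it was; a number 2.4 percentage points higher from compound 2 to compound 3 (within the scatter) shows the same for adding an ethyl to the phenyl. None of these steps left the scatter, so the series gives no sign that this position moves the read-out. The cut to methyl is deeper than any measured change, so some loss is possible, but nothing in the numbers demands it.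

Compound 4 is therefore expected at 88%, in a range from 70% to 98%. This estimate means an expected step of a number 9.4 percentage points lower from compound 3 to compound 4 (within the scatter), within the scatter.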

Compound 4, a percentage reported as inhibition, at one concentration (the size of the read-out at that concentration, not a potency): 106%
Estimate against measurement, compound 4: 18 percentage points below; measured number above the stated range.
By their numbers in this assay, from the lowest: compounds 1, 2, 3 and 4 (each within the scatter of the next, the first and the last beyond it).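

The methyl group of compound 4 holds the number in this assay even though a single carbon replaces the eight heavy atoms of 4-ethylphenyl (a number 8.6 percentage points higher from compound 3 to compound 4 (within the scatter)), so the aromatic ring on this carbon of the five-membered ring is not needed for the read-out in these compounds. Among these compounds, the other two steps are the first at this position to leave the scatter, both of modest size (a number 11 percentage points higher from compound 2 to compound 4 (beyond the scatter); a number 14.5 percentage points higher from compound 1 to compound 4 (beyond the scatter)), which shows that the group here can move the number, though compound 3 stays within the scatter of compound 4 and so goes against any simple ordering by group size. No measurement bearing on the reason for these steps is available.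

The compounds shown leave open whether hydrogen, an amine or a carboxylic acid on this aromatic carbon would hold the number, and where an ethyl or propyl chain would fall relative to methyl and pentyl. Going by these compounds, all readings in this assay come from a single concentration with the acetate groups of the core unchanged, so potency and the outcome with free hydroxyl groups in their place remain open.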